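The source may hold more compounds than are shown below. What is called first, only, known or untested is meant among the compounds shown, and "the series" means these compounds.

Compound 1, `C/C(=N\N=C1/SCC(=O)N1Cc1cccc(F)c1)c1cccs1`: > 5000000 nM
Compound 2, `CC(C)=N/N=C1\SCC(=O)N1Cc1ccc(N)cc1`: > 5000000 nM
Compound 3, `C/C(=N/N=C1\SCC(=O)N1Cc1ccc(F)cc1)c1cccs1`: > 5000000 nM

The three measured compounds share a common core and differ only in the groups attached to it. All three were tested in a physicochemical assay, with a stated time of 30 min; on this read-out higher numbers stand for weaker inhibition and lower numbers for stronger inhibition. For compound 1 the reported figure of > 5000000 nM is a limit of the assay, not a measured number. The same holds for compound 2, whose > 5000000 nM is a limit. Compound 3 likewise gives > 5000000 nM, again a limit. So compound 3 stands exactly where every measured compound stands: at the edge of what this assay can detect, with no real number behind it (the limit of > 5000000 nM in this assay, at which 3 of the 3 values shown sit). Among the measured compounds shown here, no step between two measured compounds can therefore be sized.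

Compound 4, `C/C(=N/N=C1\SCC(=O)N1Cc1ccc(F)cc1)c1ccccn1`, has not yet been measured. It differs from compound 3 in one place: pyridin-2-yl in place of thiophen-2-yl on a carbon with a double bond to nitrogen. The rest of the molecule is unchanged.

For the measured compounds named here, with no measured step to lean on, the expectation rests only on where compound 3 sits. Going by the values given here, nothing among the measured compounds suggests that this exchange would bring the value into the measurable range, so compound 4 is expected to remain at the limit as well, and the step of a number no higher from compound 3 to compound 4 (the limit leaves the size open) is estimated to be none beyond the scatter. Compound 4 is estimated at 5000000 nM, within a range from 1000000 nM to 50000000 nM, most probably reported only as a limit.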

Compound 4, half-maximal inhibitory concentration: > 5000000 nM
Compound 4: no number, only a limit; the forecaster's own chance of this, stated with the estimate: 85%; the middle value lies on the limit itself.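

Among the compounds shown here, compound 3 and compound 4 both give only a limit in this assay, so the exchange of thiophen-2-yl for pyridin-2-yl yields no step that can be read: the limit of > 5000000 nM in this assay, at which 4 of the 4 values shown sit. The compounds shown leave open how much any change to the groups on the shared core shifts the value, and whether any such change gives a real number in this assay.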